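Thiophene for phenyl on a pyridine core: a second look

The source may report more compounds than this note shows. Statements on the series, on what has been measured and on what is new or still open speak of the compounds shown alone.

Three compounds were tested in an ADME assay on HEK293 cells (Homo sapiens) for cytotoxicity, read by CCK-8 assay and cell counting, with a stated time of 2 days; a higher number here means a weaker inhibitor, a lower number a stronger inhibitor. Compound 2 `Oc1cccc(-c2cc(-c3ccccc3)nc(-c3ccc(Cl)cc3)c2)c1` gives 11600 nM. Compound 1 `Oc1cccc(-c2cc(-c3ccc(Cl)cc3)nc(-c3ccsc3)c2)c1`, which carries the change (thiophen-3-yl in place of phenyl on an aromatic carbon), gives 11200 nM; the step of a 1.0-fold lower number from compound 2 to compound 1 (0.02 log units; within the scatter) is within the scatter, so the two are not distinguished here. Compound 3 `Oc1cccc(-c2cc(-c3ccccc3)nc(-c3ccccc3Cl)c2)c1` differs from compound 2 in its core by 2-chlorophenyl in place of 4-chlorophenyl on an aromatic carbon, and in this assay compound 3 gives 1760 nM. The step of a 6.6-fold lower number from compound 2 to compound 3 (0.82 log units; beyond the scatter) is beyond the scatter, and compound 3 has the lowest number of the three.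

Compound 4 `Oc1cccc(-c2cc(-c3ccsc3)nc(-c3ccccc3Cl)c2)c1` has not been measured. It differs from compound 3 by thiophen-3-yl in place of phenyl on an aromatic carbon. Going by the values given here, this is the same kind of change as the one from compound 2 to compound 1, but the surroundings are not identical: in compound 2 the place is meta to a 4-chlorophenyl group, while in compound 3 it is meta to a 2-chlorophenyl group. Among the compounds with values here, the only measured instance of this change, a 1.0-fold lower number from compound 2 to compound 1 (0.02 log units; within the scatter), stayed within the scatter, and that is the sole basis for what follows.

For compound 4 the step of a 1.0-fold higher number from compound 3 to compound 4 (0.01 log units; within the scatter) in this assay is therefore expected to be small. The expected number for compound 4 is 1800 nM, estimated to lie between 800 nM and 4500 nM, resting on the value of compound 3, 1760 nM, and on the step of a 1.0-fold lower number from compound 2 to compound 1 (0.02 log units; within the scatter).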

Compound 4, half-maximal inhibitory concentration: 2720 nM
Beside the measured number, compound 4's estimate is 1.5-fold (0.18 log units) below it; low and high end bracket the measured number.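

In this assay, thiophen-3-yl in place of phenyl gives a 1.5-fold higher number from compound 3 to compound 4 (0.19 log units; within the scatter), and the two instances of this change do not differ: the same change on two cores in this assay, a 1.0-fold lower number (0.02 log units; within the scatter) from compound 2 to compound 1 and a 1.5-fold higher number (0.19 log units; within the scatter) from compound 3 to compound 4, 1.6-fold (0.20 log units) apart, within the scatter of two such steps. The change from 4-chlorophenyl to 2-chlorophenyl gives a 4.1-fold lower number from compound 1 to compound 4 (0.61 log units; beyond the scatter), in the same direction as the earlier step, and its two instances do not differ either: the same change on two cores in this assay, a 6.6-fold lower number (0.82 log units; beyond the scatter) from compound 2 to compound 3 and a 4.1-fold lower number (0.61 log units; beyond the scatter) from compound 1 to compound 4, 1.6-fold (0.20 log units) apart, within the scatter of two such steps. Within these four compounds, each change therefore carries from one core to the other, but this rests on only two instances of each change in a single assay and does not show that either would carry to a core outside this set or to another read-out.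

The compounds shown leave open whether thiophen-2-yl, a furan ring or a pyridine ring in place of phenyl would also leave the number in this assay unmoved. They also leave open how 3-chlorophenyl would compare with the two chlorophenyl groups shown, and what an amine or a carboxylic acid would do in place of the hydroxyl of the 3-hydroxyphenyl group.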